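A few compounds are considered here, and "the series" means these few. Any claim that something is new, unique, unknown or untested is made for them only; others in the source may bear on it.

Measured in a functional assay on HL-60 cells (Homo sapiens), read by calcium flux; on this read-out higher numbers stand for an effect only at larger amounts of compound and lower numbers for an effect already at smaller amounts:
- Compound 1 `COc1cccc(Cc2ccnn(CC(=O)Nc3ccc(Br)cc3)c2=O)c1`: > 50000 nM (a limit)
- Compound 2 `COc1cccc(Cc2cc(-c3cccs3)nn(CC(=O)Nc3ccc(F)cc3)c2=O)c1`: > 50000 nM (a limit)

Neither compound has yet given a number, and the whole picture so far is the limit of > 50000 nM in this assay, at which 2 of the 2 values shown sit. Compound 2 stands at > 50000 nM, which is a limit of this assay and not a measured potency.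

The next compound is compound 3 `COc1cccc(Cc2cc(-c3ccc(F)cc3)nn(CC(=O)Nc3ccc(F)cc3)c2=O)c1`, which carries 4-fluorophenyl in place of thiophen-2-yl on an aromatic carbon, next to the ring nitrogen and meta to a 3-methoxybenzyl group: 4-fluorophenyl in place of thiophen-2-yl on an aromatic carbon. All else stays the same.

Among the measured compounds shown here, no measured pair shows what such a swap does, so the expectation has little to rest on. Another reading at the limit is the likeliest outcome, and any number that does appear should lie close to it, on the lower side. The estimated step of an at least 1.6-fold lower number from compound 2 to compound 3 (0.22 log units; that floor lies within the scatter) is expected to be small, with nothing clearly beyond the scatter. For compound 3 the expected value is 30000 nM, with an estimated range of 6000 nM to 50000 nM.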

Compound 3, half-maximal effective concentration: > 50000 nM
Compound 3: no number, only a limit; the forecaster's own chance of this, stated with the estimate: 65%; middle value at least 1.6-fold (0.22 log units) away from the limit.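

The step from compound 2 to compound 3, 4-fluorophenyl in place of thiophen-2-yl, cannot be read, as both compounds give only a limit in this assay: the limit of > 50000 nM in this assay, at which 3 of the 3 values shown sit.
The compounds shown leave open which change to the shared core, if any, gives a measured number in this assay at all.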